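Carbamate nitrogen substitution in the shared core series

The source may hold more compounds than are shown below. What is called first, only, known or untested is meant among the compounds shown, and "the series" means these compounds.

Two compounds of this series have been run in a functional assay (Oryctolagus cuniculus) for inhibition of platelet-activating factor receptor (Cavia porcellus); a higher number here means a weaker inhibitor, a lower number a stronger inhibitor. Compound 1 `COc1cc(C(=O)N2CCN(C(=O)c3cc(OC)c(OC)c(OC)c3)C(COC(=O)NC(C)(C)C)C2)cc(OC)c1OC` gives 130 nM; compound 2 `COc1cc(C(=O)N2CCN(C(=O)c3cc(OC)c(OC)c(OC)c3)C(COC(=O)NC(C)C(C)(C)C)C2)cc(OC)c1OC` gives 170 nM. Among the measured compounds shown here, the only measured step, a 1.3-fold higher number from compound 1 to compound 2 (0.12 log units; within the scatter), is within the scatter, so the two values are not distinguished. On the numbers shown, compound 2 holds the highest number of the two, with compound 1 as its only neighbour and within the scatter of it.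

Compound 3 `CCCN(CCC)C(=O)OCC1CN(C(=O)c2cc(OC)c(OC)c(OC)c2)CCN1C(=O)c1cc(OC)c(OC)c(OC)c1` is not yet measured. Its change from compound 2, (dipropylamino in place of (1,2,2-trimethylpropyl)amino on a carbonyl carbon), keeps the atom count but removes the hydrogen-bond donor on the carbamate nitrogen and replaces a branched single chain with two unbranched ones. For the measured compounds named here, no measured step touches the substitution pattern of that nitrogen; the step from compound 1 to compound 2 only shows that enlarging the branched alkyl leaves this assay unchanged within the scatter. Going by the values given here, with no relevant precedent, the expectation is a step of moderate size at most, direction uncertain, leaning toward a somewhat higher number, so compound 3 is estimated at 250 nM, between 100 nM and 700 nM, meaning an expected step of a 1.5-fold higher number from compound 2 to compound 3 (0.17 log units; within the scatter).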

Compound 3, half-maximal inhibitory concentration: 380 nM
For compound 3 the middle estimate is 1.5-fold (0.18 log units) below the measured one; the range from low to high includes it.
By their numbers in this assay, from the lowest: compounds 1 and 2 (each within the scatter of the next); then compound 3.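

In this assay, the carbamate nitrogen is sensitive to how it is substituted, not merely to the size of its alkyl group: dipropylamino gives modest steps beyond the scatter against both branched groups (a 2.2-fold higher number from compound 2 to compound 3 (0.35 log units; beyond the scatter) and a 2.9-fold higher number from compound 1 to compound 3 (0.47 log units; beyond the scatter)), whereas enlarging the branched group alone stays within the scatter (a 1.3-fold higher number from compound 1 to compound 2 (0.12 log units; within the scatter)). The change from (1,2,2-trimethylpropyl)amino to dipropylamino keeps the heavy-atom count at the same value, so this step comes with a different arrangement of those atoms and the loss of the nitrogen hydrogen, while the substituted nitrogen remains compatible with a measurable value, as compound 3 gives 380 nM. Nothing available explains why the number rises at this position.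

The compounds shown do not separate the loss of the nitrogen hydrogen from the replacement of one branched chain by two unbranched ones, a question that propylamino on the same carbonyl carbon would address directly. They also leave open how the number responds to shorter dialkyl groups such as dimethylamino or to a ring such as piperidin-1-yl on that carbonyl carbon.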